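Swapping the pyrazole for a dimethyltriazole on the acetamide arm

The source may report more compounds than this note shows. Statements on the series, on what has been measured and on what is new or still open speak of the compounds shown alone.

In a functional assay on Venous blood for antagonist activity at C-X-C chemokine receptor type 3 (Homo sapiens), read by flow cytometry, with a stated time of 30 min, in the presence of a further agent that is not named here (on this read-out lower numbers stand for stronger inhibition and higher numbers for weaker inhibition), compound 2 `C[C@@H]1CN(c2sc(C(F)(F)F)nc2-c2nc3ccccc3[nH]2)CCN1C(=O)Cn1cccn1` gives 191 nM and stands lowest of the three measured compounds. Compound 1 `C[C@@H]1CN(c2sc(C(F)(F)F)nc2-c2nc3ccccc3[nH]2)CCN1C(=O)CN1C(=O)OC[C@@H]1c1ccccc1` gives 1380 nM, and the step of a 7.2-fold lower number from compound 1 to compound 2 (0.86 log units; beyond the scatter) is the only one measured in one place. Compound 3 `Cc1nc(C)n(CC(=O)N2CCN(c3sc(C(F)(F)F)nc3-c3nc4ccc(C(C)(C)O)c(F)c4[nH]3)C[C@H]2C)n1` gives 628 nM; it carries the same triazole arm as compound 4 but differs from it elsewhere on the shared core, so its value only hints at what that arm does. Compound 4 `Cc1nc(C)n(CC(=O)N2CCN(c3sc(C(F)(F)F)nc3-c3nc4ccccc4[nH]3)C[C@H]2C)n1` differs from compound 2 by 3,5-dimethyl-1H-1,2,4-triazol-1-yl in place of 1H-pyrazol-1-yl on a saturated chain carbon bound to a carbonyl carbon. Among the compounds with values here, no measured step bears directly on this change, and the head-group swap from compound 1 to compound 2 points only loosely. For compound 4 a modest weakening, a 2.1-fold higher number from compound 2 to compound 4 (0.32 log units; beyond the scatter), is expected, giving an estimate of 400 nM with a range from 150 nM to 1100 nM.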

Compound 4, half-maximal inhibitory concentration in the C-X-C chemokine receptor type 3 assay: 237 nM
Compound 4: the middle estimate sits 1.7-fold (0.23 log units) above what was measured, and the stated range covers the measured number.
By their numbers in the C-X-C chemokine receptor type 3 assay, from the lowest: compounds 2 and 4 (each within the scatter of the next); then compound 3; then compound 1.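

In the C-X-C chemokine receptor type 3 assay compound 2 gives 191 nM and compound 4 gives 237 nM, so the 3,5-dimethyl-1H-1,2,4-triazol-1-yl group stands level with 1H-pyrazol-1-yl on the saturated chain carbon bound to a carbonyl carbon (a 1.2-fold higher number from compound 2 to compound 4 (0.09 log units; within the scatter)). In the C-X-C chemokine receptor type 3 assay the triazole also stays well clear of the 2-oxo-4-phenyl-1,3-oxazolidin-3-yl group (a 5.8-fold lower number from compound 1 to compound 4 (0.77 log units; beyond the scatter)). In a physicochemical assay for solubility, in simulated intestinal fluid (a higher number here means a more soluble compound, a lower number a less soluble compound), compound 2 gives 352 ug/mL and compound 4 gives 440 ug/mL, and the swap likewise stays within the scatter (a 1.3-fold higher number from compound 2 to compound 4 (0.10 log units; within the scatter)). Nothing measured here accounts for these results.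

On these data alone, whether the two methyl groups and the extra ring nitrogen each matter alone stays open. So does how an amine or a carboxylic acid would read at this place.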